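Trimming an Ethyl from the Chain of Compound 3

The source may report more compounds than this note shows. Statements on the series, on what has been measured and on what is new or still open speak of the compounds shown alone.

For the measured compounds named here, in a physicochemical assay for lipophilicity, in phosphate buffer, measured as octanol-water partition, at pH 11.5 (on this read-out higher numbers stand for higher lipophilicity and lower numbers for lower lipophilicity), compound 3 `CCCCCCCCOC(=N)NC(=N)Nc1ccc(Cl)cc1` gives 5.32, the second highest of the three numbers so far. Compound 2 `CCCCCCCCCCOC(=N)NC(=N)Nc1ccc(Cl)cc1` gives 6.32, the highest of the three, while compound 1 `CCCCOC(=N)NC(=N)Nc1ccc(Cl)cc1` gives 3.32, the lowest of the three. Compound 4 `CCCCCCOC(=N)NC(=N)Nc1ccc(Cl)cc1` has not yet been measured. Its structure departs from compound 3 in one place: hydrogen in place of ethyl on a saturated chain carbon, six bonds along the chain from an oxygen on an unsaturated carbon. In words, hydrogen takes the place of ethyl on a saturated chain carbon, six bonds along the chain from an oxygen on an unsaturated carbon.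

Going by the values given here, the closest precedent is the same exchange made two bonds further out, a modest step beyond the scatter: a number 1.00 log units lower from compound 2 to compound 3 (beyond the scatter). Two large steps also bear on it: a number 2.00 log units higher from compound 1 to compound 3 (beyond the scatter) with butyl in place of hydrogen, and a number 3.00 log units higher from compound 1 to compound 2 (beyond the scatter) with hexyl in place of hydrogen. Compound 4 is therefore expected to fall between compound 1 and compound 3, a modest drop beyond the scatter in this assay. The expected step is a number 1.00 log units lower from compound 3 to compound 4 (beyond the scatter). Compound 4 is estimated at 4.32, with an expected range of 4 to 4.6.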

Compound 4, partition coefficient: 4.32
Estimate against measurement, compound 4: no gap at the digits printed; the range from low to high includes it.
By their numbers in this assay, from the lowest: compound 1; then compound 4; then compound 3; then compound 2.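

In this assay, the exchange of ethyl for hydrogen six bonds along the chain from the oxygen gives a number 1.00 log units lower from compound 3 to compound 4 (beyond the scatter), a step of the same size as the one at eight bonds along the chain, a number 1.00 log units lower from compound 2 to compound 3 (beyond the scatter). Compound 4 also completes an evenly spaced series, with a number 2.00 log units lower from compound 2 to compound 4 (beyond the scatter) and a number 1.00 log units higher from compound 1 to compound 4 (beyond the scatter), and none of the four compounds goes against that spacing. Nothing measured here explains why the steps are so even.

Whether the same spacing continues is open for a chain longer than that of compound 2 or for one shorter than that of compound 1. Also open, from the compounds shown here alone, is whether it survives a branched chain, such as isopropyl or tert-butyl, or a chain ending in an amine or a hydroxyl group.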